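A few compounds are considered here, and "the series" means these few. Any claim that something is new, unique, unknown or untested is made for them only; others in the source may bear on it.

Measured compounds in this series:

- compound 1, `ONc1ccc(CNc2cc(Br)cc3[nH]ncc23)cc1`: "not active" (no number reported)
- compound 2, `Brc1cc(NCc2cccs2)c2cn[nH]c2c1`: 54%
- compound 3, `Brc1cc(NCc2cnc[nH]2)c2cn[nH]c2c1`: 16%

All three were run in an assay for inhibition of Indoleamine 2,3-dioxygenase 1 (Homo sapiens), with a stated time of 1 h, tested at 10 uM; a lower number here means less inhibition, a higher number more inhibition at the concentration tested (going by the name of the read-out). Compound 1 carries no number, only the statement given above. Of the two numbered entries, compound 3 holds the lower value in this assay; its nearest neighbour is compound 2, and the step of a number 38 percentage points lower from compound 2 to compound 3 (beyond the scatter) is beyond the scatter, so compound 3 sits clearly under compound 2.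

The next compound, compound 4, is `Nc1nc(CNc2cc(Br)cc3[nH]ncc23)cs1`. It differs from compound 3 in one place: 2-amino-1,3-thiazol-4-yl in place of 1H-imidazol-5-yl on a saturated chain carbon bound to a nitrogen on an aromatic ring.

Within the data shown here, the only measured step that touches this position is the one from compound 2 to compound 3, where thiophen-2-yl gave way to 1H-imidazol-5-yl and the read-out fell by a number 38 percentage points lower from compound 2 to compound 3 (beyond the scatter). The group entering in compound 4, 2-amino-1,3-thiazol-4-yl, contains a sulfur atom as thiophen-2-yl does and a ring nitrogen as 1H-imidazol-5-yl does, so it stands between the two measured cases. A rise from compound 3 is therefore expected, but a partial one, and its size is uncertain given one bearing step.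

For compound 4 in this assay the estimate is 32%, within 8% to 58%, which is expected to mean a step of a number 16 percentage points higher from compound 3 to compound 4 (beyond the scatter).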

Compound 4, a percentage reported as inhibition, at one concentration (the size of the read-out at that concentration, not a potency): "not active" (no number reported)
Compound 4 has no reported number here; there is nothing to compare the estimate with.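

In this assay, among these compounds, compound 4 is recorded as "not active" (no number reported) and so no step from compound 3 to compound 4 can be read. No measurement shown offers an explanation for this result.

The compounds shown leave open how 2-amino-1,3-thiazol-4-yl compares in size of effect with 1H-imidazol-5-yl and thiophen-2-yl on a saturated chain carbon bound to a nitrogen on an aromatic ring.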